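Morpholine Amide in Place of Methoxyazetidine on a Pyridyl Acrylamide

The compounds below may be only part of what the source reports. "The series", "measured", "known", "first", "only" and "open" are said of these compounds alone.

Compound 2 `COC1CN(C(=O)/C=C/c2ccncc2-c2ccc3ccccc3c2)C1` was tested in a functional assay on A549 cells (Homo sapiens) for inhibition, read by sulforhodamine B assay, with a stated time of 72 h (on this read-out lower numbers stand for stronger inhibition of growth and higher numbers for weaker inhibition of growth), and gave > 10000 nM, which is a limit of the assay rather than a number. Compound 1 `O=C(O)/C=C/c1ccncc1-c1ccc2cc[nH]c2c1` likewise reached only the limit > 10000 nM in this assay. Compound 3 `O=C(O)/C=C/c1ccncc1-c1ccc2[nH]ccc2c1` also stands at the limit > 10000 nM in this assay. All three values share (the limit of > 10000 nM in this assay, at which 3 of the 3 values shown sit), so compound 2 cannot be ranked against its companions. Compound 4 `O=C(/C=C/c1ccncc1-c1ccc2ccccc2c1)N1CCOCC1` differs from compound 2 by morpholin-4-yl in place of 3-methoxyazetidin-1-yl on a carbonyl carbon. Among the measured compounds shown here, with every measured compound at the limit, no step between measured compounds can be read, and no shift beyond the scatter is expected, a step that the limit leaves unreadable from compound 2 to compound 4. Compound 4 is expected to give about 15000 nM in this assay, within 4000 nM to 50000 nM, most likely again as a limit.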

Compound 4, concentration for 50% growth inhibition: 8410 nM
For compound 4 the middle estimate is 1.8-fold (0.25 log units) above the measured one; the measured number falls inside the stated range.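

In this assay, among the compounds shown here, compound 4 gives 8410 nM, the first value in this set that is a number and not a limit. On these data alone, the change to morpholin-4-yl on this carbonyl carbon reads as an at least 1.1-fold lower number from compound 2 to compound 4 (0.07 log units; that floor lies within the scatter), so its true size stays unknown. No other step can be read: the limit of > 10000 nM in this assay, at which 3 of the 4 values shown sit.

As far as these compounds go, whether piperidin-1-yl or piperazin-1-yl on the same carbonyl carbon would also give a number stays open. So does whether morpholin-4-yl in place of the hydroxyl of the carboxylic acid in compound 1 would do so.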